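Working notes on solubility in a small amide series

This account rests on a few compounds, and the source may have more. Where it says the series, first, only, none or still open, it means among the compounds named here.

Measured so far:
compound 1 `Cc1ccc(-c2nc3ccccc3o2)cc1NC(=O)c1cc([N+](=O)[O-])ccc1Cl` — 310 nM
compound 2 `O=C(Nc1nc(-c2cccc(F)c2)cs1)c1cc([N+](=O)[O-])ccc1Cl` — 780 nM

In a physicochemical assay for solubility, read by spectrophotometry, in phosphate buffer, measured as kinetic solubility, with a stated time of 18 h, at pH 7.4 (on this read-out lower numbers stand for lower solubility and higher numbers for higher solubility), compound 1 gives 310 nM. Within the data shown here, compound 2, the only other measured member, gives 780 nM. Compound 1 therefore stands lowest of the two numbers, with compound 2 the nearest at a gap that lies beyond the usual scatter. Among the measured compounds shown here, the two compounds differ in several places at once, so no single step between measured compounds is available, and the gap between them cannot be tied to one structural feature.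

Compound 3 `O=C(Nc1cccc(-c2nc3ccccc3o2)c1)c1cc([N+](=O)[O-])ccc1Cl` has not yet been measured. It differs from compound 1 by hydrogen in place of methyl on an aromatic carbon. For the measured compounds named here, with no measured pair isolating this change, the expectation rests on compound 1 alone. A step of this kind is expected to be small: the number for compound 3 is expected to sit close to that of compound 1, with at most a modest rise, and quite possibly no change beyond the scatter. On that basis the expected step of a 1.3-fold higher number from compound 1 to compound 3 (0.11 log units; within the scatter) is a slight increase. Compound 3 is estimated at 400 nM, within a range of 150 nM to 1000 nM.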

Compound 3, solubility: 470 nM
Beside the measured number, compound 3's estimate is 1.2-fold (0.07 log units) below it; low and high end bracket the measured number.
By their numbers in this assay, from the lowest: compounds 1, 3 and 2 (each within the scatter of the next, the first and the last beyond it).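

In this assay, the change to hydrogen in place of methyl on an aromatic carbon, ortho to a large group and para to a 1,3-benzoxazol-2-yl group, gives a 1.5-fold higher number from compound 1 to compound 3 (0.18 log units; within the scatter) and so stays inside the usual scatter. Among these compounds, this is the first pair that differs in one place, so this position can now be read on its own rather than through compounds that differ in several places at once. Among the compounds shown here, on this core, the methyl group can be removed without a step that stands clear of the scatter, although this single pair shows only this one change on this one core.

No separate measurement accompanies this pair to account for the reading.

Whether an amine, a carboxylic acid or a longer chain at this same position would give a step beyond the scatter remains open, as the compounds shown carry only methyl or hydrogen there. Compound 1 and compound 2 still differ in several places at once, and their gap remains untied to any single structural feature.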